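Cyclopropyl Amide to Ethylcarbamoyl on a Shared Diaryl Ether Core

The source may report more compounds than this note shows. Statements on the series, on what has been measured and on what is new or still open speak of the compounds shown alone.

Compound 1 `CCC(=O)Nc1ccc(Oc2cccc(OC)c2)cc1` and compound 2 `COc1cccc(Oc2ccc(NC(=O)C3CC3)cc2)c1` share one core and differ only at the carbonyl carbon. In an assay on isolated protein for binding affinity to melatonin receptor type 1B (Homo sapiens) (on this read-out higher numbers stand for weaker inhibition and lower numbers for stronger inhibition), compound 1 gives 6.8 nM, while compound 2 gives 13 nM. The step of a 1.9-fold higher number from compound 1 to compound 2 (0.28 log units; within the scatter) is small, so compound 2 stands highest of the two numbers only in the narrowest sense, its gap to compound 1 lying within the scatter.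

Compound 3 `CCNC(=O)Nc1ccc(Oc2cccc(OC)c2)cc1` carries the change (ethylamino in place of cyclopropyl on a carbonyl carbon). Among the compounds with values here, no measured step bears directly on this change: the one step known swaps two small carbon groups on the carbonyl and stays within the scatter, whereas here a nitrogen-bearing group enters in place of a carbon ring. The two measured compounds show only that the carbonyl substituent can be varied between ethyl and cyclopropyl without a step beyond the scatter. Given that the entering group is of a different kind, the expectation is a modest step of a 1.9-fold higher number from compound 2 to compound 3 (0.28 log units; within the scatter), tending toward a higher number but uncertain in direction. Compound 3 is therefore estimated at 25 nM, with a range from 6 nM to 100 nM.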

Compound 3, inhibition constant: 250 nM
For compound 3 the middle estimate is 10-fold (1.00 log units) below the measured one; measured number above the stated range.
By their numbers in this assay, from the lowest: compounds 1 and 2 (each within the scatter of the next); then compound 3.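

Within the data shown here, replacing a carbon group on the carbonyl carbon with ethylamino is the first change at this position that moves the read-out in this assay beyond the scatter, with a 19-fold higher number from compound 2 to compound 3 (1.28 log units; beyond the scatter) and, measured against the ethyl group, a 37-fold higher number from compound 1 to compound 3 (1.57 log units; beyond the scatter) on the same core. The position therefore does not accept every small substituent alike: swapping ethyl for cyclopropyl gave only a 1.9-fold higher number from compound 1 to compound 2 (0.28 log units; within the scatter) and ethylamino has the same number of heavy atoms as cyclopropyl, but it brings a nitrogen and a hydrogen-bond donor to the carbonyl carbon, and inhibition is clearly weaker with it. Nothing in hand explains why this exchange weakens inhibition so much.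

The compounds shown do not separate the contribution of the nitrogen from that of its hydrogen, and a dimethylamino group on the same carbonyl carbon, which keeps the nitrogen but has no such hydrogen, would bear directly on that. They also leave open whether a methylamino group or a longer chain on the nitrogen would move the number further or bring it back.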